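The source may report more compounds than this note shows. Statements on the series, on what has been measured and on what is new or still open speak of the compounds shown alone.

Measured in a functional assay on RAW264.7 cells (Mus musculus) for inhibition, read by Griess assay, with stated times of 1 h and 24 h (a lower number here means a stronger inhibitor, a higher number a weaker inhibitor), each value a limit of the assay and not a number:

compound 1 `Cc1noc(CC2OC(=O)c3ccccc32)n1`: > 10000 nM
compound 2 `O=C1OC(Cc2nc(-c3ccccc3)no2)c2ccccc21`: > 10000 nM
compound 3 `COCCOc1ccc(C(O)C2OC(=O)c3c(OC)cc(OC)cc32)cc1`: > 10000 nM

Compound 3 thus offers only a limit, > 10000 nM. The whole set sits there: the limit of > 10000 nM in this assay, at which 3 of the 3 values shown sit.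

Compound 4 `COc1cc(OC)c2c(c1)C(C(O)c1ccc(OCc3ccc(Cl)cc3)cc1)OC2=O` follows from compound 3 by one change: 4-chlorophenyl in place of methoxymethyl on a saturated chain carbon bound to an oxygen on an aromatic ring. Put another way, 2-methoxyethoxy gives way to (4-chlorobenzyl)oxy. Going by the values given here, the only measured step, a step that the two limits leave unreadable from compound 1 to compound 2, involves a different change and gives no size to carry over. With no readable step to go on, this assay offers no firm direction, and only a modest shift is expected. The expected change is a step that the limit leaves unreadable from compound 3 to compound 4. Compound 4 is estimated at 12000 nM, with an expected range of 3000 nM to 40000 nM.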

Compound 4, half-maximal inhibitory concentration: 4320 nM
Estimate against measurement, compound 4: 2.8-fold (0.44 log units) above; the range from low to high includes it.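

In this assay, going by these compounds alone, replacing 2-methoxyethoxy with (4-chlorobenzyl)oxy gives the first readable step in the set, an at least 2.3-fold lower number from compound 3 to compound 4 (0.36 log units; beyond the scatter). A change on a saturated chain carbon bound to an oxygen on an aromatic ring can therefore bring a compound off the limit. The step from compound 1 to compound 2 cannot be read, and compound 4 alone carries a number rather than a limit: the limit of > 10000 nM in this assay, at which 3 of the 4 values shown sit.

It remains open whether the chlorine or the phenyl ring carries this step, as no plain benzyl stands among the compounds shown. On these data alone, how an amine or a carboxylic acid on this chain would read also remains open.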